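The compounds below may be only part of what the source reports. "The series", "measured", "known", "first", "only" and "open" are said of these compounds alone.

Compound 1 `COC(=O)[C@@H]1COC(/C=C/c2ccc(OC)cc2)=N1` and compound 2 `COC(=O)[C@@H]1COC(/C=C/c2ccc(C)cc2)=N1` share one core and differ in a single place: methyl in place of methoxy on an aromatic carbon. Both were tested in an ADME assay on Vero cells (Chlorocebus sabaeus) for cytotoxicity, read by WST assay, tested at 50 ug/mL; a lower number here means a stronger effect, a higher number a weaker effect of the compound at the concentration tested. Compound 1 gives 94.8%, and compound 2 gives 85.1%, so that the step of a number 9.7 percentage points lower from compound 1 to compound 2 (within the scatter) is recorded. Compound 3 `COC(=O)c1coc(/C=C/c2ccc(OC)cc2)n1` carries the same methoxy-bearing side chain on a different core; the difference between the two cores is not broken down here. In this assay compound 3 gives 99.6%, a number close to that of compound 1 and beyond the scatter from that of compound 2. Within the data shown here, compound 4 `COC(=O)c1coc(/C=C/c2ccc(C)cc2)n1` has not yet been measured; it is related to compound 3 by methyl in place of methoxy on an aromatic carbon, the same kind of change as the one from compound 1 to compound 2, and the place is described in the same words for both pairs. The step is expected to be small again, estimated as a number 7.6 percentage points lower from compound 3 to compound 4 (within the scatter), because the measured pair showed a number 9.7 percentage points lower from compound 1 to compound 2 (within the scatter), a change within the scatter. Compound 4 is therefore expected to give about 92%, with a likely range from 82% to 101%.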

Compound 4, a percentage reported as activity, at one concentration (the size of the read-out at that concentration, not a potency): 102%
Compound 4: the middle estimate sits 10 percentage points below what was measured; the measured number lies above the stated range.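

In this assay, methyl in place of methoxy on an aromatic carbon produces a number 2.4 percentage points higher from compound 3 to compound 4 (within the scatter), so on this second core, as on the first, the change does not move the read-out beyond normal variation. Set beside the earlier step, the new one cannot be told apart from it: the same change on two cores in this assay, a number 9.7 percentage points lower (within the scatter) from compound 1 to compound 2 and a number 2.4 percentage points higher (within the scatter) from compound 3 to compound 4, 12.1 percentage points apart, within the scatter of two such steps. The two cores therefore agree that this swap makes little measurable difference at the concentration tested, but this does not show that the change acts identically on both, since steps this small cannot reveal a real difference between them, and the opposite signs of the two steps carry no meaning.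

The compounds shown vary only between methoxy and methyl in this one place, on two cores, and all of them keep the same methyl ester. On these data alone, what an amine or a longer chain in that place would do remains open, as does the effect of a carboxylic acid in place of the ester.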